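From 2-fluorobenzyl to 2,4-dichlorobenzyl in a flat series

A few compounds are considered here, and "the series" means these few. Any claim that something is new, unique, unknown or untested is made for them only; others in the source may bear on it.

In a functional assay on K562 cells (Homo sapiens) for cytotoxicity, read by MTT assay, with a stated time of 48 h (a lower number here means a stronger inhibitor, a higher number a weaker inhibitor), compound 1 (`Cc1ccc(CN2CCN(C(=O)CN[C@H]3CCN(S(=O)(=O)Cc4ccccc4)C3)CC2)cc1`) gives 8200 nM, compound 2 (`O=C(CN[C@H]1CCN(S(=O)(=O)Cc2ccccc2)C1)N1CCN(Cc2cccc(Cl)c2)CC1`) gives 8600 nM and compound 3 (`O=C(CN[C@H]1CCN(S(=O)(=O)Cc2ccccc2)C1)N1CCN(Cc2ccccc2F)CC1`) gives 12600 nM, which places compound 3 within the scatter of both others. Compound 4 (`O=C(CN[C@H]1CCN(S(=O)(=O)Cc2ccccc2)C1)N1CCN(Cc2ccc(Cl)cc2Cl)CC1`) carries 2,4-dichlorophenyl in place of 2-fluorophenyl on a saturated chain carbon bound to an amine nitrogen in a ring. Three measured exchanges at this place bear on it: a 1.0-fold higher number from compound 1 to compound 2 (0.02 log units; within the scatter), a 1.5-fold higher number from compound 1 to compound 3 (0.19 log units; within the scatter) and a 1.5-fold higher number from compound 2 to compound 3 (0.17 log units; within the scatter). Going by the values given here, all three stay within the scatter, although no measured compound carries the 2,4-dichlorophenyl group. The expected change is a 1.6-fold lower number from compound 3 to compound 4 (0.20 log units; within the scatter), a slightly lower number that is not expected to exceed the scatter. For compound 4 the estimated value is 8000 nM, with an expected range from 3500 nM to 15000 nM.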

Compound 4, half-maximal inhibitory concentration: 4300 nM
The estimate for compound 4 lay 1.9-fold (0.27 log units) above the measured number; measured number inside the range.
By their numbers in this assay, from the lowest: compounds 4, 1, 2 and 3 (each within the scatter of the next, the first and the last beyond it).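

Going by these compounds alone, the 2,4-dichlorophenyl group gives the first exchange at this position in this assay that passes the scatter (a 2.9-fold lower number from compound 3 to compound 4 (0.47 log units; beyond the scatter)). Against the other two groups it stays within the scatter (a 2.0-fold lower number from compound 2 to compound 4 (0.30 log units; within the scatter); a 1.9-fold lower number from compound 1 to compound 4 (0.28 log units; within the scatter)), so only the two ends of the series separate. Nothing measured here explains this step.

The compounds shown leave open whether both chlorine atoms are needed, since 4-chlorophenyl does not appear among them. They also leave open how a pyridine ring or a carboxylic acid on the aromatic ring would fare at this position.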